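Smaller Substituent on a Coumarin-like Core: Expected Inhibition

The source may report more compounds than this note shows. Statements on the series, on what has been measured and on what is new or still open speak of the compounds shown alone.

Compound 1, `CCOC(=O)COc1cc(=O)oc2cc(OCc3cccc(Cl)c3)ccc12`: 0%
Compound 2, `O=c1cc(CCl)c2ccc(OCc3cccc(Br)c3)cc2o1`: 28%

In an assay on isolated protein (strain Sprague-Dawley) for inhibition of Amine oxidase [flavin-containing] A (Rattus norvegicus), read by spectrophotometry, with a stated time of 5 min, tested at 10 uM (a lower number here means less inhibition, a higher number more inhibition at the concentration tested (going by the name of the read-out)), compound 1 gives 0%, the lowest of the two numbers shown. Compound 2 gives 28%, a gap that lies beyond the usual scatter. Compound 3, `O=Cc1cc(=O)oc2cc(OCc3cccc(Cl)c3)ccc12`, keeps the core of compound 1 and differs in one spot: formyl in place of (ethoxycarbonyl)methoxy on an aromatic carbon. For the measured compounds named here, no measured pair shows this exact exchange, so its effect is unknown. Compound 3 is expected to show a small gain over compound 1, of a number 15 percentage points higher from compound 1 to compound 3 (beyond the scatter), close to the edge of scatter. Compound 3 is estimated at 15%, within 0% to 40%.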

Compound 3, a percentage reported as inhibition, at one concentration (the size of the read-out at that concentration, not a potency): 14%
Beside the measured number, compound 3's estimate is 1 percentage points above it; the range from low to high includes it.
By their numbers in this assay, from the lowest: compound 1; then compound 3; then compound 2.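

On the aromatic carbon opposite the ring oxygen, formyl in place of (ethoxycarbonyl)methoxy gives a number 14 percentage points higher from compound 1 to compound 3 (beyond the scatter) in this assay, the first step read at this position. The inhibition at this position therefore responds to the group it carries, and the shorter formyl gives the higher number in this pair. Nothing available explains the step.

As far as these compounds go, a single exchange gives no trend, so it remains open how an amine, a carboxylic acid or a longer chain on this carbon would compare with formyl.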